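Inverting Two Ring Stereocentres in a Cyclic Peroxide Acid

The compounds below may be only part of what the source reports. "The series", "measured", "known", "first", "only" and "open" are said of these compounds alone.

Measured compounds:
compound 1 `C=C1CCCC(C)(C)C1CC[C@]1(C)CC[C@@H]([C@@H](C)C(=O)O)OO1`, > 10000 nM;
compound 2 `C=C1CCCC(C)(C)C1CC[C@]1(C)CC[C@H]([C@@H](C)C(=O)OC)OO1`, 8140 nM;
compound 3 `C=C1CCC[C@H]2[C@](C)(CC[C@]3(C)CC[C@@H]([C@@H](C)C(=O)O)OO3)[C@@H](C)CC[C@]12C`, 1060 nM.

Of the compounds shown here, three have been tested in a functional assay on HCT-116 cells (Homo sapiens) for inhibition; on this read-out higher numbers stand for weaker inhibition of growth and lower numbers for stronger inhibition of growth. Compound 1 stands at the edge of what this assay reports: its value is a limit, not a number, as shown by the limit of > 10000 nM in this assay, at which 1 of the 3 values shown sits. Compound 2, which carries a methyl ester in place of the acid and a differently drawn ring stereocentre, gives a number, and compound 3, built on a larger core, gives the lowest number of the three. No two of these compounds differ in only one place, so no single step can be read off from them.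

Compound 4 `C=C1CCCC(C)(C)C1CC[C@@]1(C)CC[C@H]([C@@H](C)C(=O)O)OO1` differs from compound 1 as follows: the two compounds have the same atoms and bonds; at least one stereo element is drawn with a configuration in one of them and without one in the other: 2 of 4 stereo elements differ; a stereocentre at a saturated ring carbon is drawn R in compound 1 and S in compound 4; a stereocentre at a saturated ring carbon is drawn S in compound 1 and R in compound 4. Going by the values given here, nothing among the measured compounds isolates such a change in configuration. In this assay, among the compounds with values here, the step of an at least 1.1-fold lower number from compound 1 to compound 4 (0.04 log units; that floor lies within the scatter) is expected to be small, most likely none beyond the scatter, since compound 1 itself sits at the limit and no measured pair shows how inverting these centres acts. Compound 4 is therefore expected to give 9000 nM, within a range from 2500 nM to 30000 nM, with a fair chance that only a limit is reported again.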

Compound 4, concentration for 50% growth inhibition: 5190 nM
For compound 4 the middle estimate is 1.7-fold (0.24 log units) above the measured one, and the stated range covers the measured number.
By their numbers in this assay, from the lowest: compound 3; then compounds 4 and 2 (each within the scatter of the next). At a limit, above all of these: compound 1.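

In this assay compound 1 gives > 10000 nM, which is a limit and not a number. Inverting two saturated ring stereocentres, one drawn R becoming S and one drawn S becoming R, leaves all atoms and bonds the same and gives the only step here that isolates a change in configuration: an at least 1.9-fold lower number from compound 1 to compound 4 (0.28 log units; that floor lies within the scatter). Compound 4 therefore gives a true number for this arrangement of the shared core, but the full size of the step cannot be read, because one end of it is not a number: the limit of > 10000 nM in this assay, at which 1 of the 4 values shown sits.

From the compounds shown here alone, whether one inverted centre or both together account for the step stays open, and the comparison also needs caution, since the two drawings are not defined to the same extent: the fact that one of compounds 1 and 4 is drawn with a defined configuration and the other without, at the place where they differ Also open is how this inverted arrangement would behave on the core of compound 3, or with an amide or a hydroxamic acid in place of the carboxylic acid.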